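The source may hold more compounds than are shown below. What is called first, only, known or untested is meant among the compounds shown, and "the series" means these compounds.

In a functional assay on V79 cells (Cricetulus griseus) for cytotoxicity, read by colony formation (on this read-out higher numbers stand for weaker inhibition and lower numbers for stronger inhibition), compound 1 `CC1(CN)CCN(c2nc3c(cc2F)c(=O)c(C(=O)O)cn3C2CC2)C1` gives 25 ug/mL and compound 2 `CNCC1(C)CCN(c2nc3c(cc2F)c(=O)c(C(=O)O)cn3C2CC2)C1` gives 58 ug/mL, the higher of the two numbers. Compound 3 `O=C(O)c1cn(C2CC2)c2nc(N3CCNCC3)c(F)cc2c1=O` carries piperazin-1-yl in place of 3-methyl-3-((methylamino)methyl)pyrrolidin-1-yl on an aromatic carbon. Among the measured compounds shown here, only one measured step bears on this, and only loosely: methyl in place of hydrogen on an amine nitrogen gave a 2.3-fold higher number from compound 1 to compound 2 (0.37 log units; beyond the scatter), a modest change. For the measured compounds named here, no measured compound carries piperazin-1-yl, so only a small move towards a lower number is expected, within the usual scatter. The expected step is a 1.3-fold lower number from compound 2 to compound 3 (0.11 log units; within the scatter). Compound 3 is estimated at 45 ug/mL, with an expected range of 18 ug/mL to 110 ug/mL.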

Compound 3, half-maximal inhibitory concentration: 120 ug/mL
Compound 3: the middle estimate sits 2.7-fold (0.43 log units) below what was measured; measured number outside the range, above it.
By their numbers in this assay, from the lowest: compound 1; then compound 2; then compound 3.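

Compound 3 shows that in this assay the number responds to replacing the whole amine ring on this aromatic carbon, not only to a methyl on an amine nitrogen. Piperazin-1-yl gives a 2.1-fold higher number from compound 2 to compound 3 (0.32 log units; beyond the scatter) and a 4.8-fold higher number from compound 1 to compound 3 (0.68 log units; beyond the scatter), so both steps point to weaker inhibition. No measurement shown here accounts for this shift.

From the compounds shown here alone, it remains open whether the six-membered ring or the loss of the pyrrolidine side chain matters. Plain pyrrolidin-1-yl or 4-methylpiperazin-1-yl on the shared core would help separate the two.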